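The source may hold more compounds than are shown below. What is called first, only, known or untested is meant among the compounds shown, and "the series" means these compounds.

Working notes, step from compound 3 to compound 4.

Among the measured compounds shown here, compound 3 `O=C(Nc1ccc(Oc2ccc(-c3ncc[nH]3)cc2)cc1)Nc1ccc(Cl)c([N+](=O)[O-])c1` gives 12.4% in a functional assay on A549 cells (Homo sapiens) for inhibition, read by MTT assay and WST assay, with a stated time of 72 h, tested at 10 uM (on this read-out higher numbers stand for more inhibition of growth at the one concentration tested and lower numbers for less inhibition of growth), the second highest of the three numbers so far. Its nearest neighbour is compound 2 `O=C(Nc1ccccc1)Nc1ccc(Oc2ccc(-c3ncc[nH]3)cc2)cc1`, which gives 7.09% in this assay; the gap a number 5.3 percentage points higher from compound 2 to compound 3 (within the scatter) is within the scatter. The furthest is compound 1 `O=C(Nc1ccc(Oc2ccc(-c3nccs3)cc2)cc1)Nc1ccc(F)c(C(F)(F)F)c1`, which gives 76.4% in this assay, beyond the scatter from compound 3.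

Compound 4 `O=C(Nc1ccc(Oc2ccc(-c3ncc[nH]3)cc2)cc1)Nc1ccc(F)c(C(F)(F)F)c1` arises from compound 3 by the change (4-fluoro-3-(trifluoromethyl)phenyl in place of 4-chloro-3-nitrophenyl on an amide-type nitrogen). For the measured compounds named here, no measured step has exactly this exchange. Going by the values given here, the only step on the shared core, a number 5.3 percentage points higher from compound 2 to compound 3 (within the scatter), shows that one aryl swap on that nitrogen moved little. Compound 1 carries the same 4-fluoro-3-(trifluoromethyl)phenyl as compound 4 but on a different core, so its number can only hint at an upward direction, not fix the size. A moderate rise in this assay is therefore expected, with wide uncertainty. Compound 4 is estimated at 30%, range 8% to 62%. The expected step is a number 17.6 percentage points higher from compound 3 to compound 4 (beyond the scatter).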

Compound 4, percent growth inhibition at one concentration: 63.3%
For compound 4 the middle estimate is 33.3 percentage points below the measured one; measured number above the stated range.
By their numbers in this assay, from the lowest: compounds 2 and 3 (each within the scatter of the next); then compound 4; then compound 1.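

On the shared core, the group on the amide-type nitrogen can decide the outcome in this assay: the 4-fluoro-3-(trifluoromethyl)phenyl group gives a number 50.9 percentage points higher from compound 3 to compound 4 (beyond the scatter) and a number 56.2 percentage points higher from compound 2 to compound 4 (beyond the scatter), both large steps, so this position is not as flat as the earlier aryl swap suggested. With that group held constant, 1H-imidazol-2-yl in place of 1,3-thiazol-2-yl on an aromatic carbon gives a modest change, a number 13.1 percentage points lower from compound 1 to compound 4 (beyond the scatter), so the high number largely survives this exchange of the core. No measurement on hand accounts for the large steps.

The compounds shown leave open whether the fluoro or the trifluoromethyl part of the entering group carries the rise. Also open, from the compounds shown here alone, is how a pyridyl ring or a cyclohexyl group on the same nitrogen would read in this assay.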